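The source may hold more compounds than are shown below. What is called first, only, known or untested is meant among the compounds shown, and "the series" means these compounds.

Measured in a functional assay on MKN-45 cells (Homo sapiens) for cytotoxicity, read by MTT assay, with a stated time of 72 h (a lower number here means a stronger inhibitor, a higher number a weaker inhibitor), so far:

compound 1 `CN(C)CCn1cnnc1-c1cc(Oc2ccc(NC(=O)N/N=C/c3ccc(Cl)cc3Cl)cc2F)ccn1` — 750 nM
compound 2 `CN(C)CCn1cnnc1-c1cc(Oc2ccc(NC(=O)N/N=C/c3c(Cl)cccc3Cl)cc2F)ccn1` — 160 nM
compound 3 `CN(C)CCn1cnnc1-c1cc(Oc2ccc(NC(=O)N/N=C/c3ccc(F)cc3F)cc2F)ccn1` — 810 nM

Compound 2 gives the lowest number of the three in this assay: its nearest neighbour is compound 1, a 4.7-fold lower number from compound 1 to compound 2 (0.67 log units; beyond the scatter), and its furthest is compound 3, a 5.1-fold higher number from compound 2 to compound 3 (0.70 log units; beyond the scatter). Compound 1 and compound 3 sit together, a 1.1-fold higher number from compound 1 to compound 3 (0.03 log units; within the scatter).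

Compound 4 `COc1cc(/C=N/NC(=O)Nc2ccc(Oc3ccnc(-c4nncn4CCN(C)C)c3)c(F)c2)ccc1O` is not yet measured. It differs from compound 2 at one place: 4-hydroxy-3-methoxyphenyl in place of 2,6-dichlorophenyl on a carbon with a double bond to nitrogen. The measured steps all concern the same ring on the carbon with the double bond to nitrogen. Both of them show that leaving 2,6-dichlorophenyl for another substituted phenyl gives a higher number, a 5.1-fold higher number from compound 2 to compound 3 (0.70 log units; beyond the scatter) and, read backwards, a 4.7-fold lower number from compound 1 to compound 2 (0.67 log units; beyond the scatter). For the measured compounds named here, no step covers a ring carrying a hydroxy or methoxy group, so the direction is expected from those two steps alone: a higher number in this assay, of about the same size, though the range must be wide. For compound 4 the estimate is 1000 nM, between 300 nM and 4000 nM, which is expected to mean a 6.3-fold higher number from compound 2 to compound 4 (0.80 log units; beyond the scatter).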

Compound 4, half-maximal inhibitory concentration: 3780 nM
The estimate for compound 4 lay 3.8-fold (0.58 log units) below the measured number, and the stated range covers the measured number.
By their numbers in this assay, from the lowest: compound 2; then compounds 1 and 3 (each within the scatter of the next); then compound 4.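

In this assay, 4-hydroxy-3-methoxyphenyl on the carbon with a double bond to nitrogen gives the highest number of the four compounds, and a 24-fold higher number from compound 2 to compound 4 (1.37 log units; beyond the scatter) is the largest step yet seen at this position. The other two steps, a 4.7-fold higher number from compound 3 to compound 4 (0.67 log units; beyond the scatter) and a 5.0-fold higher number from compound 1 to compound 4 (0.70 log units; beyond the scatter), show that this ring also stands apart from the 2,4-difluorophenyl and 2,4-dichlorophenyl rings, which are within the scatter of each other, so the position separates more than the 2,6-dichlorophenyl ring from the rest. Nothing available explains the rise, and this single change cannot assign it to the hydroxy group, the methoxy group or the two together.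

Open, going by these compounds, is whether a ring carrying only a hydroxy group or only a methoxy group behaves like compound 4. Also open, on these data alone, is whether 2,6-difluorophenyl or a ring bearing an amine stays near compound 2 or moves towards compound 4.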